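The source may hold more compounds than are shown below. What is called first, only, known or untested is meant among the compounds shown, and "the series" means these compounds.

Of the compounds shown here, two have numbers so far in a functional assay on LNCaP cells (Homo sapiens) for antiproliferative activity, read by propidium iodide staining, with a stated time of 96 h; on this read-out higher numbers stand for weaker inhibition and lower numbers for stronger inhibition. Compound 1 (`CC(O)(CSc1ccccc1OC(F)(F)F)C(=O)Nc1cccc(S(F)(F)(F)(F)F)c1`) gives 10000 nM. Compound 2 (`CC1(C)C(=O)N(c2ccc(C#N)cc2C(F)(F)F)C(=S)N1c1ccc(S(F)(F)(F)(F)F)cc1`) gives 3000 nM, the lower of the two numbers, and the gap between them lies beyond the scatter. Compound 3 (`CC1(C)C(=O)N(c2ccc([N+](=O)[O-])cc2C(F)(F)F)C(=S)N1c1ccc(S(F)(F)(F)(F)F)cc1`) keeps the rest of compound 2 but carries nitro in place of cyano on an aromatic carbon, meta to a trifluoromethyl group and para to a large group: nitro in place of cyano on an aromatic carbon. Within the data shown here, no measured pair shows this change, so the data give no direct guide to its size. In this assay, a step within the scatter is expected, with no favoured direction. The expected step is no change at the digits printed from compound 2 to compound 3 (within the scatter). For compound 3 the estimated value is 3000 nM, with an expected range of 1000 nM to 9000 nM.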

Compound 3, half-maximal inhibitory concentration: 100000 nM
Beside the measured number, compound 3's estimate is 33-fold (1.52 log units) below it; measured number above the stated range.
By their numbers in this assay, from the lowest: compound 2; then compound 1; then compound 3.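

In this assay, among these compounds, the aromatic carbon meta to a trifluoromethyl group and para to a large group is the first place where a single change can be read: nitro in place of cyano gives a 33-fold higher number from compound 2 to compound 3 (1.52 log units; beyond the scatter) with the rest of compound 2 kept. The group on this carbon therefore has a large bearing on the read-out, and nitro cannot stand in for cyano here. No measurement at hand bears on why these two groups part so widely.

On these data alone, whether an amine, a carboxylic acid or a simple methyl group on this carbon would read closer to compound 2 or to compound 3 stays open. Also open, as far as these compounds go, is whether the same swap would give a step of like size without the trifluoromethyl group on the ring.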